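A few compounds are considered here, and "the series" means these few. Any claim that something is new, unique, unknown or untested is made for them only; others in the source may bear on it.

Compound 1 `Brc1cccc(C2=NCCCC2)c1` is the reference point of this small set. In an assay on cell membranes for displacement of a labelled ligand from Neuronal acetylcholine receptor; alpha4/beta2 (Rattus norvegicus), read by radioligand binding, with a stated time of 30 min (on this read-out higher numbers stand for weaker inhibition and lower numbers for stronger inhibition), compound 1 gives 5020 nM, the lower of the two numbers recorded so far. Going by the values given here, its one measured neighbour is compound 2 `Brc1cc(Br)cc(C2=NCCCC2)c1`, which in this assay gives 18800 nM; the step of a 3.7-fold higher number from compound 1 to compound 2 (0.57 log units; beyond the scatter) shows that adding a second bromo weakens binding modestly.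

The unmeasured compound 3 `Oc1cccc(C2=NCCCC2)c1` differs from compound 1 in one place: hydroxy in place of bromo on an aromatic carbon. Among the compounds with values here, no measured step here swaps one group for another at that position; the only step available, a 3.7-fold higher number from compound 1 to compound 2 (0.57 log units; beyond the scatter), concerns an added bromo elsewhere on the ring and so bears on this change only loosely. Hydroxy is a smaller substituent than bromo, and with no direct precedent the expected step of a 1.3-fold lower number from compound 1 to compound 3 (0.10 log units; within the scatter) is small, within the scatter or not far beyond it. Compound 3 is therefore estimated at 4000 nM, with a range from 800 nM to 20000 nM.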

Compound 3, inhibition constant: 32000 nM
Estimate against measurement, compound 3: 8.0-fold (0.90 log units) below; the whole stated range lies below it.
By their numbers in this assay, from the lowest: compound 1; then compounds 2 and 3 (each within the scatter of the next).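

In this assay, going by these compounds alone, the step of a 6.4-fold higher number from compound 1 to compound 3 (0.80 log units; beyond the scatter) is the first direct exchange of one group for another on this aromatic carbon, and it runs towards weaker inhibition. It shows that, at this place, hydroxy does not stand in for bromo without loss, although each group counts a single heavy atom and only hydroxy brings a hydrogen-bond donor and acceptor. No evidence on the cause of this difference is available here.

The compounds shown leave open whether a chloro, a methoxy or an amine at this position would give a number closer to that of compound 1 or to that of compound 3. They also leave open whether hydroxy in place of bromo on compound 2 would give a step of similar size.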